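The source may hold more compounds than are shown below. What is called first, only, known or untested is meant among the compounds shown, and "the series" means these compounds.

Measured compounds:
Compound 1 `CC(C)CCc1ccc2c(NCCCNCc3ccco3)ccnc2c1` — 4200 nM in a physicochemical assay for solubility, with a stated time of 18 h, at pH 7.4; a lower number here means a less soluble compound, a higher number a more soluble compound
Compound 2 `COc1ccc(Oc2ccc3c(NCCCNCc4cccc(OC)c4O)ccnc3c2)cc1` — 14500 nM in this assay
Compound 3 `COc1cccc(CNCCCNc2ccnc3cc(-c4ccc(C(F)(F)F)cc4)ccc23)c1O` — 32000 nM in this assay

Compound 3 stands highest of the three numbers in this assay; its nearest neighbour is compound 2 and the furthest is compound 1. Going by the values given here, the one step that is counted, a 2.2-fold higher number from compound 2 to compound 3 (0.34 log units; beyond the scatter), is a modest change that lies beyond the scatter.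

Compound 4 `COc1cccc(CNCCCNc2ccnc3cc(CCC(C)C)ccc23)c1O` is the next compound, and it differs from compound 3 in one place: isopentyl in place of 4-(trifluoromethyl)phenyl on an aromatic carbon. The counted step between compound 2 and compound 3 concerns a different exchange and does not bear directly on this one. Among the compounds with values here, what does bear on it is compound 1, which carries the same isopentyl group at the same place of its core and gives 4200 nM, a lower number than compound 3, though compound 1 also differs elsewhere and no step is counted between them. On that basis compound 4 is expected to fall below compound 3, by roughly a 2.7-fold lower number from compound 3 to compound 4 (0.43 log units; beyond the scatter), and its expected value in this assay is 12000 nM, with a range from 4000 nM to 36000 nM.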

Compound 4, solubility: 4200 nM
For compound 4 the middle estimate is 2.9-fold (0.46 log units) above the measured one; the range from low to high includes it.
By their numbers in this assay, from the lowest: compounds 1 and 4 (each within the scatter of the next); then compound 2; then compound 3.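

In this assay, isopentyl on this aromatic carbon, which is meta to a fused ring and para to a fused ring, gives a lower number than either aromatic group, with a 7.6-fold lower number from compound 3 to compound 4 (0.88 log units; beyond the scatter) and a 3.5-fold lower number from compound 2 to compound 4 (0.54 log units; beyond the scatter). With isopentyl held in place, 2-hydroxy-3-methoxyphenyl in place of furan-2-yl on the saturated chain carbon bound to an amine nitrogen gives no change at the digits printed from compound 1 to compound 4 (within the scatter), so that exchange does not move the number in this pair. No measurement is available that accounts for these differences.

The compounds shown leave open whether the exchange of furan-2-yl for 2-hydroxy-3-methoxyphenyl would also leave the number unmoved with 4-(trifluoromethyl)phenyl or 4-methoxyphenoxy on the aromatic carbon. They also leave open where a carboxylic acid, an amine or a longer chain at that carbon would stand.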